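The source may hold more compounds than are shown below. What is called first, only, known or untested is meant among the compounds shown, and "the series" means these compounds.

Among the compounds with values here, compound 2, whose structure is `COc1ccc(-c2nnc(Nc3csc(-c4ccccc4)c3)s2)cc1`, is the one member of this small set with a numerical result: in a functional assay on A549 cells (Homo sapiens) for inhibition, read by colorimetric assay and MTT assay, with a stated time of 72 h (a higher number here means a weaker inhibitor, a lower number a stronger inhibitor), compound 2 gives 8000 nM. Its two companions carry no number. For compound 1, with the structure `Cc1ccc(-c2nnc(Nc3csc(-c4ccccc4)c3)s2)cc1`, this assay records "not determined" (no result reported), and for compound 3, with the structure `COc1ccc(-c2nnc(Nc3csc(-c4ccc(C)cc4)c3)s2)cc1`, this assay likewise records "not determined" (no result reported). Compound 2 therefore stands alone on the numbers shown, with nothing to compare it against.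

Compound 4, whose structure is `Oc1ccc(-c2nnc(Nc3csc(-c4ccccc4)c3)s2)cc1`, has not yet been tested. Compared with compound 2, the change is hydrogen in place of methyl on an oxygen on an aromatic ring, so that methoxy becomes hydroxy and 4-methoxyphenyl becomes 4-hydroxyphenyl. Within the data shown here, no pair of measured compounds in this set differs in just one place, so there is no measured step to lean on. With a change this small, the expectation is a step within the usual scatter, in no particular direction. The step from compound 2 to compound 4 is expected to be about no change at the digits printed from compound 2 to compound 4 (within the scatter). Compound 4 is accordingly estimated at 8000 nM, within a range from 3000 nM to 20000 nM.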

Compound 4, half-maximal inhibitory concentration: 15000 nM
For compound 4 the middle estimate is 1.9-fold (0.27 log units) below the measured one, within the range that was stated.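

Within the data shown here, this is the first step in the set that can be read. In this assay, replacing methoxy with hydroxy gives a 1.9-fold higher number from compound 2 to compound 4 (0.27 log units; within the scatter) and so shows that, for this pair, the methyl on the oxygen can give way to hydrogen without moving the result outside what repeated measurements would be expected to show, which the lone value of compound 2 could not reveal. Nothing available offers an explanation of this result.

An amine, a carboxylic acid or a longer chain such as ethoxy at this same place on the aromatic ring remains an open case, so this single pair says nothing about how far the position tolerates change beyond hydrogen and methyl. On these data alone, the entries for compound 1 and compound 3 hold no number, so steps involving them cannot be read, and the effect of the other changes they carry, methyl in place of methoxy in compound 1 and an added methyl on the far phenyl in compound 3, remains unknown.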